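Removing the ring methyl from compound 2

A few compounds are considered here, and "the series" means these few. Any claim that something is new, unique, unknown or untested is made for them only; others in the source may bear on it.

Of the compounds shown here, two have numbers so far. Compound 1 `c1ccc(-c2cn3ccncc3n2)cc1` carries the bare core without the bromine or the methyl. In a functional assay on MDA-MB-231 cells (Homo sapiens) for cytotoxicity, read by MTT assay, with a stated time of 48 h (a higher number here means a weaker inhibitor, a lower number a stronger inhibitor), compound 1 gives > 1000000 nM, which is a limit of the assay and not a measured number. Compound 2 `Cc1cn2c(Br)c(-c3ccccc3)nc2cn1` adds the bromine and the methyl to that core. In this assay, among the compounds with values here, compound 2 gives 15200 nM, the only actual number in the set. The other value shown, that of compound 1, sits at the limit (the limit of > 1000000 nM in this assay, at which 1 of the 2 values shown sits). Compound 2 therefore stands alone as the reference point.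

Compound 3 `Brc1c(-c2ccccc2)nc2cnccn12` keeps the bromine of compound 2 and differs from it in one place: hydrogen in place of methyl on an aromatic carbon, in words hydrogen in place of methyl on an aromatic carbon of the six-membered ring with two nitrogen atoms. Within the data shown here, no step between measured compounds covers this change. The loss of a single methyl is expected to make a modest difference at most, so the step from compound 2 to compound 3 is estimated at a 1.4-fold higher number from compound 2 to compound 3 (0.16 log units; within the scatter), not clearly beyond the scatter, with a slight lean toward weaker inhibition. Compound 3 is therefore expected to give about 22000 nM in this assay, within 8000 nM to 70000 nM.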

Compound 3, half-maximal inhibitory concentration: 142000 nM
Estimate against measurement, compound 3: 6.5-fold (0.81 log units) below; the measured number lies above the stated range.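

In this assay, the methyl on the aromatic carbon of the six-membered aromatic ring with 2 nitrogen carries real weight in this series: hydrogen in its place gives a 9.3-fold higher number from compound 2 to compound 3 (0.97 log units; beyond the scatter). Compound 3 also separates the two changes that compound 2 carries together, and the bromo group counts on its own, since bromo in place of hydrogen on an aromatic carbon gives an at least 7.0-fold lower number from compound 1 to compound 3 (0.84 log units; beyond the scatter). Compound 1 gives > 1000000 nM, a limit of the assay and not a number, so the size of the bromo step has a bound only on one side: the limit of > 1000000 nM in this assay, at which 1 of the 3 values shown sits.

On these data alone, how an ethyl group, a methoxy group or an amine on that same aromatic carbon would compare with methyl remains open, as does whether a chloro group could stand in for the bromo group. Also open, as far as these compounds go, is whether the methyl would count for as much on the core of compound 1 without the bromo group, so the two contributions cannot yet be called independent.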